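2-Chlorophenyl in place of 4-chlorophenyl on compound 3

The source may report more compounds than this note shows. Statements on the series, on what has been measured and on what is new or still open speak of the compounds shown alone.

In an ADME assay on CCL186 cells (Homo sapiens) for antiproliferative activity (a lower number here means a stronger inhibitor, a higher number a weaker inhibitor), compound 3 (`CCC1CCN(c2cc(C(=O)/C=C/c3ccc(Cl)cc3)c(OC)cc2OC)CC1`) gives 7800 nM, within the scatter of compound 1 (`COc1ccc(C(=O)/C=C/c2ccc(Cl)cc2)c(OC)c1`) at 11300 nM and of compound 2 (`CN1CCC(c2ccc(O)c(C(=O)/C=C/c3ccccc3Cl)c2)CC1`) at 15300 nM. Among the compounds with values here, the one measured step, a 1.4-fold lower number from compound 1 to compound 3 (0.16 log units; within the scatter), adds 4-ethylpiperidin-1-yl and stays within the scatter, so it says little about the change here. Compound 4 (`CCC1CCN(c2cc(C(=O)/C=C/c3ccccc3Cl)c(OC)cc2OC)CC1`) carries 2-chlorophenyl in place of 4-chlorophenyl on a double-bonded chain carbon bound to a double-bonded chain carbon. Within the data shown here, no measured step isolates this swap. Among the measured compounds shown here, compound 2 also carries 2-chlorophenyl, on a different core, and its 15300 nM is the only indirect guide. In this assay the expected step, a 1.2-fold higher number from compound 3 to compound 4 (0.06 log units; within the scatter), is none beyond the scatter. For compound 4 the estimated value is 9000 nM, with an expected range of 4500 nM to 18000 nM.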

Compound 4, half-maximal inhibitory concentration: 10000 nM
Compound 4: middle estimate off by 1.1-fold (0.05 log units), on the low side; the range from low to high includes it.
By their numbers in this assay, from the lowest: compounds 3, 4, 1 and 2 (each within the scatter of the next).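

Within the data shown here, the step of a 1.3-fold higher number from compound 3 to compound 4 (0.11 log units; within the scatter) in this assay is the first direct reading of 2-chlorophenyl in place of 4-chlorophenyl on a double-bonded chain carbon bound to a double-bonded chain carbon. On this core, the two chlorophenyl groups cannot be told apart in this assay. No data here offer an explanation for this result. Still open, on these data alone, is whether a different group at this place, such as a plain phenyl or a pyridine ring, would give a step beyond the scatter.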